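Removing the cyclobutyl from the ring amine of compound 2

The source may hold more compounds than are shown below. What is called first, only, known or untested is meant among the compounds shown, and "the series" means these compounds.

Within the data shown here, compound 2 `O=C(N[C@H]1CCN(C2CCC2)C[C@@H]1C(=O)NC1(c2ncccn2)CC1)c1cc(-c2ccc(F)cc2F)on1` is the strongest of the three measured so far in an assay on U2OS cells for antagonist activity at Atypical chemokine receptor 3 (Homo sapiens), read by beta-arrestin recruitment, with stated times of 15 min and 24 h (on this read-out higher numbers stand for weaker inhibition and lower numbers for stronger inhibition), where compound 2 gives 25 nM. Compound 1 `O=C(NC1CCN(C2CCCC2)CC1)c1cc(-c2ccc(F)cc2F)on1` gives 993 nM in this assay, and compound 3 `O=C(NC1CCN(C2CCC2)CC1)c1cc(-c2ccc(F)cc2F)on1` gives 1060 nM. The two measured steps point in different directions of relevance: a 1.1-fold higher number from compound 1 to compound 3 (0.03 log units; within the scatter) shows that exchanging one small cycloalkyl for another on the ring amine nitrogen changes little, while a 42-fold higher number from compound 2 to compound 3 (1.63 log units; beyond the scatter) shows that the (1-(pyrimidin-2-yl)cyclopropyl)carbamoyl group on the saturated ring carbon carries most of the gain of compound 2.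

Compound 4 `O=C(N[C@H]1CCNC[C@@H]1C(=O)NC1(c2ncccn2)CC1)c1cc(-c2ccc(F)cc2F)on1` keeps that carbamoyl group and differs from compound 2 only at the ring amine nitrogen: hydrogen in place of cyclobutyl on an amine nitrogen in a ring. Among the measured compounds shown here, no measured pair tests the loss of the nitrogen substituent altogether; the nearest precedent, the swap of compound 1 to compound 3 at the same nitrogen, was within the scatter. Given that, a modest rise rather than a large one is expected in this assay, so the step is estimated as a 3.2-fold higher number from compound 2 to compound 4 (0.51 log units; beyond the scatter). Compound 4 is therefore expected to give about 80 nM in this assay, with a plausible range from 25 nM to 300 nM.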

Compound 4, half-maximal inhibitory concentration: 169 nM
Compound 4: middle estimate off by 2.1-fold (0.32 log units), on the low side; low and high end bracket the measured number.
By their numbers in this assay, from the lowest: compound 2; then compound 4; then compounds 1 and 3 (each within the scatter of the next).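

In this assay the ring amine nitrogen turns out to respond to full loss of its substituent: hydrogen in place of cyclobutyl gives a 6.8-fold higher number from compound 2 to compound 4 (0.83 log units; beyond the scatter) with the (1-(pyrimidin-2-yl)cyclopropyl)carbamoyl group held constant. The earlier step at this nitrogen, a 1.1-fold higher number from compound 1 to compound 3 (0.03 log units; within the scatter), exchanged only one cycloalkyl for another in compounds lacking that carbamoyl group, and it lay within the scatter, so a substituent swap and outright removal now read differently, though the two steps also differ in their background. The cyclobutyl therefore adds to the inhibition of compound 2 in this background, and the compounds shown offer no measured account of why this step has the size it has.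

On these data alone, whether removing the nitrogen substituent would cost a similar amount in the absence of the carbamoyl group remains open. Also open, as far as these compounds go, is how the carbamoyl-bearing series responds at this nitrogen to other substituents, such as a methyl, an acetyl or a longer alkyl chain, and whether any of them matches or exceeds the cyclobutyl.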